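Dropping One Methyl Group: Only a Small Shift Expected

The compounds below may be only part of what the source reports. "The series", "measured", "known", "first", "only" and "open" are said of these compounds alone.

Compound 2 `COc1cc(-c2cc(/C=C/C(=O)c3ccc(C)cc3)nc3cc(-c4ccccc4)nn23)cc(OC)c1OC` holds the lowest of the two numbers measured in a functional assay on A549 cells (Homo sapiens) for antiproliferative activity, read by MTT assay, with a stated time of 24 h (on this read-out higher numbers stand for weaker inhibition and lower numbers for stronger inhibition), where compound 2 gives 19400 nM. Its nearest neighbour, compound 1 `COc1cc(-c2cc(C(=O)/C=C/c3ccc(Cl)cc3)nc3cc(-c4ccccc4)nn23)cc(OC)c1OC`, gives 23800 nM in this assay. The step of a 1.2-fold lower number from compound 1 to compound 2 (0.09 log units; within the scatter) lies within the scatter. Compound 3 `COc1cc(-c2cc(/C=C/C(=O)c3ccccc3)nc3cc(-c4ccccc4)nn23)cc(OC)c1OC` differs from compound 2 by hydrogen in place of methyl on an aromatic carbon, on an aromatic carbon of a six-membered aromatic ring of carbon only, para to a large group. Within the data shown here, no measured step touches this change, and the single available step, a 1.2-fold lower number from compound 1 to compound 2 (0.09 log units; within the scatter), concerns another part of the molecule. A step no larger than the scatter is therefore expected, a 1.1-fold higher number from compound 2 to compound 3 (0.05 log units; within the scatter). Compound 3 is estimated at 22000 nM, ranging from 9000 nM to 55000 nM.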

Compound 3, half-maximal inhibitory concentration: 18200 nM
The estimate for compound 3 lay 1.2-fold (0.08 log units) above the measured number; low and high end bracket the measured number.
By their numbers in this assay, from the lowest: compounds 3, 2 and 1 (each within the scatter of the next).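

In this assay hydrogen in place of methyl gives a 1.1-fold lower number from compound 2 to compound 3 (0.03 log units; within the scatter) and so shows that this position, on the 4-methylphenyl ring, tolerates losing the methyl group with no change that can be read. Replacing the (2-(4-chlorophenyl)ethenyl)carbonyl group with 2-benzoylethenyl likewise gives a 1.3-fold lower number from compound 1 to compound 3 (0.12 log units; within the scatter) and stays within the scatter. Nothing measured here bears on why these numbers lie so close. As far as these compounds go, whether an amine or a carboxylic acid at this position would move the number beyond the scatter remains open.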